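Chain-end variation on the benzamide series: compound 4

This account rests on a few compounds, and the source may have more. Where it says the series, first, only, none or still open, it means among the compounds named here.

The series is built on the core of compound 1 `CCCCCN1CCC(NC(=O)c2cc(Cl)c(N)cc2OC)CC1`, which in a functional assay on HEK293 cells for activation of 5-hydroxytryptamine receptor 4 (Homo sapiens), read by cAMP accumulation (a lower number here means a smaller maximal response, a higher number a larger maximal response), gives > 100%; this is a limit of the assay, not a number. Compound 2 `COc1cc(N)c(Cl)cc1C(=O)NC1CCN(CCCCCO)CC1` gives > 100% in this assay, again only a limit. Compound 3 `COc1cc(N)c(Cl)cc1C(=O)NC1CCN(CCCCCCCCO)CC1` gives > 100% in this assay, also a limit. Compound 3 therefore stands where all three values shown stand, at the limit of > 100% in this assay, at which 3 of the 3 values shown sit, and the steps a step that the two limits leave unreadable from compound 1 to compound 2, a step that the two limits leave unreadable from compound 1 to compound 3 and a step that the two limits leave unreadable from compound 2 to compound 3 cannot be given a size.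

Compound 4 `COc1cc(N)c(Cl)cc1C(=O)NC1CCN(CCCCCN2C(=O)c3ccccc3C2=O)CC1` is not yet measured. It differs from compound 3 by a group of 11 heavy atoms (8 carbon, 1 nitrogen, 2 oxygen; one five-membered non-aromatic ring with 1 hetero atom, one six-membered aromatic ring of carbon only) in place of a group of 4 heavy atoms (3 carbon, 1 oxygen; no ring), on a saturated chain carbon, five bonds along the chain from an amine nitrogen in a ring.

The measured steps that bear on this change are those at the same chain position, a step that the two limits leave unreadable from compound 1 to compound 3 and a step that the two limits leave unreadable from compound 2 to compound 3; neither is readable because every value sits at the limit of > 100% in this assay, at which 3 of the 3 values shown sit. No direction can be taken from them, and no step beyond the scatter is expected from compound 3 to compound 4, the step of a number no higher from compound 3 to compound 4 (the limit leaves the size open) being the estimate. Compound 4 is accordingly expected to give about 100%, within 85% to 110%, most probably again reported only as a limit.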

Compound 4, intrinsic activity: the largest response reached, in percent of the reference agonist's: > 100%
Compound 4: a limit, no number; the forecaster's own chance of this, stated with the estimate: 70%; the middle value lies on the limit itself.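

In this assay compound 4 gives > 100%, which is a limit and not a number. The steps to compound 4 from compound 1, compound 2 and compound 3 cannot be read, because every value sits at the same limit: the limit of > 100% in this assay, at which 4 of the 4 values shown sit.

The compounds shown leave open how large each maximal response is and whether these chain ends differ at all.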